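The source may hold more compounds than are shown below. What is called first, only, known or untested is meant among the compounds shown, and "the series" means these compounds.

Measured so far:
- compound 1, `COCCCNc1ncc(C(Oc2ccc3cc(Br)ccc3c2)c2ccc(Cl)cc2)s1`: "not toxic" (no number reported)
- compound 2, `COc1ccc(C(=O)Nc2ncc(C(Oc3ccc4cc(Br)ccc4c3)c3ccc(Cl)cc3)s2)cc1`: > 50000 nM

Both compounds share a core, and the piece follows what happens when the group on the ring nitrogen of compound 2 is exchanged. In an ADME assay on HepG2 2.2.15 cells (Homo sapiens) for cytotoxicity (a lower number here means that less compound is tolerated, a higher number that more compound is tolerated), compound 2 reaches only a limit of the assay, > 50000 nM, so its true value is not known as a single number. That places compound 2 at the limit of > 50000 nM in this assay, at which 1 of the 2 values shown sits, with compound 1 recorded as "not toxic" (no number reported) in this assay. Among the measured compounds shown here, no step between two measured compounds is available, so no measured direction can be read off.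

Compound 3, `O=S(=O)(Nc1ncc(C(Oc2ccc3cc(Br)ccc3c2)c2ccc(Cl)cc2)s1)c1ccccc1`, is not yet measured. It differs from compound 2 in one place: phenylsulfonyl in place of (4-methoxyphenyl)carbonyl on a nitrogen on an aromatic ring. Both groups on that nitrogen carry the same count of hydrogen-bond acceptors and no donor, and both bring one six-membered aromatic ring of carbon only.

Given that compound 2 sits at the limit of > 50000 nM in this assay, at which 1 of the 2 values shown sits, the expected outcome for compound 3 is that this assay again reports only a limit, so the step that the limit leaves unreadable from compound 2 to compound 3 is estimated to lie within the scatter. The estimate for compound 3 in this assay is 60000 nM, with a range from 20000 nM to 150000 nM.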

Compound 3, half-maximal cytotoxic concentration: > 50000 nM
Compound 3: no number, only a limit; the forecaster's own chance of this, stated with the estimate: 70%; the middle value is on the limit's open side.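

Among the compounds shown here, compound 3, like compound 2, gives only a limit and no single number in this assay, so no step between compound 2 and compound 3 can be read. The compounds shown leave open at what concentration any of them harms these cells, and whether phenylsulfonyl and (4-methoxyphenyl)carbonyl on that nitrogen differ at all.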